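The source may report more compounds than this note shows. Statements on the series, on what has been measured and on what is new or still open speak of the compounds shown alone.

Compound 2 `O=S(=O)(c1cc(F)cc(F)c1)c1cnc2c(F)cccc2c1-c1ccc(Cl)cc1` gives 0.73 mL/min in an ADME assay on microsomes from liver (Homo sapiens) for metabolic stability, tested at 2.5 uM; on this read-out higher numbers stand for fast clearance and lower numbers for slow clearance. Compound 1 `O=S(=O)(c1cc(F)cc(F)c1)c1cnc2c(F)cccc2c1-c1cccc(F)c1` differs from it by 3-fluorophenyl in place of 4-chlorophenyl on an aromatic carbon and gives 1.18 mL/min, a step of a 1.6-fold higher number from compound 2 to compound 1 (0.21 log units; within the scatter). Compound 3 `Cc1ccc(S(=O)(=O)c2cnc3c(F)cccc3c2-c2ccc(Cl)cc2)cc1F` differs from compound 2 by 3-fluoro-4-methylphenyl in place of 3,5-difluorophenyl on a sulfonyl sulfur; compound 3 gives 2.2 mL/min, a step of a 3.0-fold higher number from compound 2 to compound 3 (0.48 log units; beyond the scatter). Compound 4 `Cc1ccc(S(=O)(=O)c2cnc3c(F)cccc3c2-c2cccc(F)c2)cc1F` has not yet been measured; it differs from compound 3 by 3-fluorophenyl in place of 4-chlorophenyl on an aromatic carbon, the same change that was made from compound 2 to compound 1, at a place described in the same words. Within the data shown here, the step expected from compound 3 to compound 4 is a 1.6-fold higher number from compound 3 to compound 4 (0.20 log units; within the scatter), set beside the earlier step because a 1.6-fold higher number from compound 2 to compound 1 (0.21 log units; within the scatter) is the only guide to this change, and that guide rests on a single measured pair. The number expected for compound 4 is 3.5 mL/min, estimated to lie between 1.8 mL/min and 7 mL/min.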

Compound 4, intrinsic clearance in a liver preparation (reported as CLH), per the amount of preparation that the assay uses: 3.92 mL/min
For compound 4 the middle estimate is 1.1-fold (0.05 log units) below the measured one; the range from low to high includes it.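

In this assay, 3-fluorophenyl in place of 4-chlorophenyl gives a 1.8-fold higher number from compound 3 to compound 4 (0.25 log units; within the scatter), and this matches the same change on the other core: the same change on two cores in this assay, a 1.6-fold higher number (0.21 log units; within the scatter) from compound 2 to compound 1 and a 1.8-fold higher number (0.25 log units; within the scatter) from compound 3 to compound 4, 1.1-fold (0.04 log units) apart, within the scatter of two such steps. Putting 3-fluoro-4-methylphenyl in place of 3,5-difluorophenyl on the sulfonyl sulfur gives a 3.3-fold higher number from compound 1 to compound 4 (0.52 log units; beyond the scatter), and this step also carries over: the same change on two cores in this assay, a 3.0-fold higher number (0.48 log units; beyond the scatter) from compound 2 to compound 3 and a 3.3-fold higher number (0.52 log units; beyond the scatter) from compound 1 to compound 4, 1.1-fold (0.04 log units) apart, within the scatter of two such steps. Among these compounds, each change therefore kept its size across these cores, but each comparison rests on only one pair of steps, and the steps for the first change are themselves within the scatter, so neither result shows that the changes would carry over to other cores.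

As far as these compounds go, it remains open whether the steps would hold on a core carrying an amine or a carboxylic acid. The same question applies if either aromatic group gives way to a longer chain.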